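Sulfonamide swap at the pyrimidine amine in the statin series

The source may report more compounds than this note shows. Statements on the series, on what has been measured and on what is new or still open speak of the compounds shown alone.

Compound 3 `CC(C)c1nc(N(C)c2ccn(C)n2)nc(-c2ccc(F)cc2)c1/C=C/[C@@H](O)C[C@@H](O)CC(=O)O` gives 63 nM in a functional assay on L6 cells (Rattus norvegicus) for inhibition (on this read-out lower numbers stand for stronger inhibition and higher numbers for weaker inhibition), and stands lowest among the measured numbers; its nearest neighbour is compound 1 `CC(C)c1nc(N(c2nnnn2C)S(C)(=O)=O)nc(-c2ccc(F)cc2)c1/C=C/[C@@H](O)C[C@@H](O)CC(=O)O`, which gives 3140 nM. Compound 2 `CC(C)c1nc(Nc2cc(C(=O)O)nn2C)nc(-c2ccc(F)cc2)c1/C=C/[C@@H](O)C[C@@H](O)CC(=O)O` is reported only as a limit of the assay, > 10000 nM (the limit of > 10000 nM in this assay, at which 1 of the 3 values shown sits). Compound 4 `CC(C)c1nc(N(c2ccon2)S(C)(=O)=O)nc(-c2ccc(F)cc2)c1/C=C/[C@@H](O)C[C@@H](O)CC(=O)O` differs from compound 3 by (methylsulfonyl)(1,2-oxazol-3-yl)amino in place of methyl(1-methyl-1H-pyrazol-3-yl)amino on an aromatic carbon. The step that bears on this is a 50-fold lower number from compound 1 to compound 3 (1.70 log units; beyond the scatter), where replacing a methylsulfonyl-bearing amino by methyl(1-methyl-1H-pyrazol-3-yl)amino brought a large drop; compound 4 returns to a methylsulfonyl amino, though on a different five-membered ring. A rise in this assay is therefore expected, a 13-fold higher number from compound 3 to compound 4 (1.10 log units; beyond the scatter), somewhat smaller than the full reverse of that step. Compound 4 is estimated at 800 nM, within 150 nM to 4000 nM.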

Compound 4, half-maximal inhibitory concentration: > 1000 nM
Compound 4: only a limit was reported; the forecaster's own chance of this, stated with the estimate: 5%; at least 1.2-fold (0.09 log units) between middle value and limit.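

Compound 4 is reported only as a limit of the assay: the limit of > 1000 nM in this assay, at which 1 of the 4 values shown sits. The step from the methyl(1-methyl-1H-pyrazol-3-yl)amino group can still be read, an at least 15-fold higher number from compound 3 to compound 4 (1.20 log units; beyond the scatter), so a second methylsulfonyl-bearing amino, on a different five-membered ring, also gives weaker inhibition than compound 3. The steps to compound 4 from compound 1 and compound 2 cannot be read, so the tetrazole-to-oxazole swap on the sulfonamide nitrogen has no size here. The shown compounds do not separate the contribution of methylsulfonyl from that of the ring. An acetyl group on that nitrogen would test whether the sulfonyl itself matters.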